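Substituent on the ring nitrogen of the shared core

The source may hold more compounds than are shown below. What is called first, only, known or untested is meant among the compounds shown, and "the series" means these compounds.

Compound 1 `Cn1c(=O)c(-c2cccc([N+](=O)[O-])c2)nc2ccccc21` gives in an assay on cells for activation of Cystic fibrosis transmembrane conductance regulator (Homo sapiens), read by fluorescence, with a stated time of 10 min (on this read-out lower numbers stand for an effect already at smaller amounts and higher numbers for an effect only at larger amounts of compound), only the limit > 10000 nM. Compound 2 `CCn1c(=O)c(-c2cccc([N+](=O)[O-])c2)nc2ccccc21` gives 65 nM and compound 3 `C=CCn1c(=O)c(-c2cccc([N+](=O)[O-])c2)nc2ccccc21` gives 55 nM; compound 3 holds the lowest of the two numbers, with compound 2 within the scatter of it. The steps of an at least 150-fold lower number from compound 1 to compound 2 (2.18 log units; beyond the scatter) and an at least 180-fold lower number from compound 1 to compound 3 (2.25 log units; beyond the scatter) are large, while a 1.2-fold lower number from compound 2 to compound 3 (0.07 log units; within the scatter) stays within the scatter. Compound 4 `O=c1c(-c2cccc([N+](=O)[O-])c2)nc2ccccc2n1Cc1ccccn1` differs from compound 3 by pyridin-2-yl in place of vinyl on a saturated chain carbon bound to an aromatic nitrogen. Among the compounds with values here, the only step that swaps one group for another on a saturated chain carbon bound to an aromatic nitrogen, a 1.2-fold lower number from compound 2 to compound 3 (0.07 log units; within the scatter), was within the scatter; the large steps concern hydrogen alone. Compound 4 is therefore expected at 60 nM (range 20 nM to 200 nM). This estimate means an expected step of a 1.1-fold higher number from compound 3 to compound 4 (0.04 log units; within the scatter).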

Compound 4, half-maximal effective concentration: 52 nM
Compound 4: the middle estimate sits 1.2-fold (0.06 log units) above what was measured; low and high end bracket the measured number.
By their numbers in this assay, from the lowest: compounds 4, 3 and 2 (each within the scatter of the next). At a limit, above all of these: compound 1.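

Pyridin-2-yl brings a six-membered aromatic ring and a hydrogen-bond acceptor onto the saturated chain carbon bound to an aromatic nitrogen, yet the steps stay within the scatter: a 1.1-fold lower number from compound 3 to compound 4 (0.02 log units; within the scatter) and a 1.3-fold lower number from compound 2 to compound 4 (0.10 log units; within the scatter). Against hydrogen, this larger group gives a large step, like methyl and vinyl: an at least 190-fold lower number from compound 1 to compound 4 (2.28 log units; beyond the scatter). That step rests on compound 1, which is known only as a limit: the limit of > 10000 nM in this assay, at which 1 of the 4 values shown sits.

Going by these compounds, whether an amine, a carboxylic acid or a longer chain at this place would fit the same range remains open. So does whether phenyl would match pyridin-2-yl.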